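The compounds below may be only part of what the source reports. "The series", "measured", "known", "first", "only" and "open" are said of these compounds alone.

Measured so far:
Compound 1 `Cc1ccc(-c2nnc(SCc3ccc(Cl)nc3)o2)cc1`: 3.62 ug/mL
Compound 2 `Clc1ccc(-c2nnc(SCc3ccc(Cl)nc3)o2)cc1`: 8.62 ug/mL

Within the data shown here, in a functional assay on SGC-7901 cells (Homo sapiens) for antiproliferative activity, read by MTT assay, with a stated time of 48 h (on this read-out lower numbers stand for stronger inhibition and higher numbers for weaker inhibition), compound 2 gives 8.62 ug/mL, the higher of only two numbers, which makes it the weaker inhibitor of the pair. Compound 3 `Clc1ccc(CSc2nnc(-c3ccco3)o2)cn1` has not yet been measured. It differs from compound 2 in one place, with furan-2-yl in place of 4-chlorophenyl on an aromatic carbon.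

Among the measured compounds shown here, only one measured step bears on this change, and only indirectly: a 2.4-fold higher number from compound 1 to compound 2 (0.38 log units; beyond the scatter), with chloro in place of methyl on an aromatic carbon. For the measured compounds named here, that step is modest, but it alters a single substituent, and no measured pair exchanges a whole ring. Its size is therefore a rough guide at best. A step of similar modest size is expected here, and a larger one in either direction cannot be ruled out. With compound 1 at 3.62 ug/mL as the only other reference, the expectation leans slightly towards a lower number. The expected step is a 1.4-fold lower number from compound 2 to compound 3 (0.16 log units; within the scatter). For compound 3 the estimated value is 6 ug/mL, with an expected range from 2 ug/mL to 20 ug/mL.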

Compound 3, half-maximal inhibitory concentration: 14.3 ug/mL
Compound 3: middle estimate off by 2.4-fold (0.38 log units), on the low side; measured number inside the range.
By their numbers in this assay, from the lowest: compound 1; then compounds 2 and 3 (each within the scatter of the next).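

At this position, on an aromatic carbon of a five-membered aromatic ring with 2 nitrogen and 1 oxygen, the series now includes the exchange of a whole ring, and in this assay furan-2-yl in place of 4-chlorophenyl gives a 1.7-fold higher number from compound 2 to compound 3 (0.22 log units; within the scatter), so this exchange shows no effect that can be told from the usual scatter. The same furan-2-yl in place of 4-methylphenyl gives a 4.0-fold higher number from compound 1 to compound 3 (0.60 log units; beyond the scatter), which shows that 4-methylphenyl alone stands apart among the three groups and that compound 1 is the strongest inhibitor of the three. Nothing available on these compounds accounts for this pattern.

The compounds shown leave open whether the methyl group itself matters, and whether a longer chain such as ethyl or propyl on the phenyl ring, or an amine or a methoxy group there, would give numbers closer to compound 1 or to compound 3. They also leave open whether a saturated ring such as cyclohexyl would be tolerated at this position.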